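The source may hold more compounds than are shown below. What is called first, only, known or untested is meant among the compounds shown, and "the series" means these compounds.

Measured so far in a functional assay on MCF7 cells (Homo sapiens) for antiproliferative activity, read by MTT assay, with a stated time of 72 h; a lower number here means a stronger inhibitor, a higher number a weaker inhibitor:
Compound 1 `C=CC(=O)Nc1cccc(Oc2nc(Nc3cccc(OC)c3)nc3c2CSCC3)c1`: > 50000 nM, a limit
Compound 2 `COc1cccc(Nc2nc3c(c(Oc4cccc(NC(=O)C=C(C)C)c4)n2)CSCC3)c1`: > 50000 nM, a limit
Compound 3 `COc1cccc(Nc2nc3c(c(Oc4cccc(NC(=O)/C=C/C(C)C)c4)n2)CSCC3)c1`: 21800 nM

Compound 2 gives no number, only a limit, and it stands at the limit of > 50000 nM in this assay, at which 2 of the 3 values shown sit. Compound 4 `CC(C)=CC(=O)Nc1cccc(Oc2nc(Nc3cccc(C#N)c3)nc3c2CSCC3)c1` differs from compound 2 by a single change: cyano in place of methoxy on an aromatic carbon. Cyano takes the place of methoxy on an aromatic carbon, meta to a large group.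

Among the compounds with values here, none of the measured steps touches this place, as all three change the group on the carbonyl carbon. The first, a step that the two limits leave unreadable from compound 1 to compound 2, cannot be read. The other two are an at least 2.2-fold lower number from compound 1 to compound 3 (0.36 log units; beyond the scatter) and an at least 2.2-fold lower number from compound 2 to compound 3 (0.36 log units; beyond the scatter). They show that a change at the carbonyl end can bring a number within reach in this assay, with compound 3 at 21800 nM, but they say nothing about exchanging methoxy for cyano.

No step beyond the scatter is therefore expected, in either direction. This expectation rests on compound 2, whose > 50000 nM is a limit. The expected step is an at least 1.2-fold lower number from compound 2 to compound 4 (0.09 log units; that floor lies within the scatter). For compound 4 the estimated value is 40000 nM, with an expected range from 15000 nM to 80000 nM, and a report of only a limit would not be surprising.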

Compound 4, half-maximal inhibitory concentration: > 50000 nM
Compound 4 gave a limit, no number (the forecaster's own chance of this, stated with the estimate: 60%); middle value at least 1.2-fold (0.09 log units) from the limit.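

Compound 4, like compound 2, gives only a limit, so the step between these two compounds cannot be read, and the result joins the others at that limit: the limit of > 50000 nM in this assay, at which 3 of the 4 values shown sit. The compounds shown leave open whether cyano in place of methoxy on an aromatic carbon changes the antiproliferative value at all.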